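Cyclopropylmethyl in Place of Pyridylmethyl on the Aminopyrimidine Series

This account rests on a few compounds, and the source may have more. Where it says the series, first, only, none or still open, it means among the compounds named here.

Of the compounds shown here, three sharing one core have been measured in a functional assay on HEK293 cells for agonist activity at G-protein coupled receptor 39 (Homo sapiens), read by inositol phosphate accumulation; on this read-out lower numbers stand for an effect already at smaller amounts and higher numbers for an effect only at larger amounts of compound. Compound 1 `CNc1nc(NCc2ccc(Cl)cc2)cc(-c2ccccn2)n1` gives 15 nM, compound 2 `CNc1nc(NCC2CCCCC2)cc(-c2ccccn2)n1` gives 11 nM, and compound 3 `CNc1nc(NCc2ccncc2)cc(-c2ccccn2)n1` gives 87 nM. Compound 3 stands highest of the three numbers; the nearest is compound 1 and the furthest is compound 2, both beyond the scatter. The steps are a 1.4-fold lower number from compound 1 to compound 2 (0.13 log units; within the scatter), a 5.8-fold higher number from compound 1 to compound 3 (0.76 log units; beyond the scatter) and a 7.9-fold higher number from compound 2 to compound 3 (0.90 log units; beyond the scatter).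

Compound 4 `CNc1nc(NCC2CC2)cc(-c2ccccn2)n1` differs from compound 3 as follows: cyclopropyl in place of pyridin-4-yl on a saturated chain carbon bound to a nitrogen on an aromatic ring. The bearing steps are those that carry a ring onto the same chain carbon: the cyclohexyl-to-pyridin-4-yl step a 7.9-fold higher number from compound 2 to compound 3 (0.90 log units; beyond the scatter) and the 4-chlorophenyl-to-pyridin-4-yl step a 5.8-fold higher number from compound 1 to compound 3 (0.76 log units; beyond the scatter), both of modest size and both raising the number. Moving back from pyridin-4-yl to a saturated carbon ring is expected to reverse part of that, giving a lower number in this assay; the step is estimated as a 4.4-fold lower number from compound 3 to compound 4 (0.64 log units; beyond the scatter). Compound 4 is therefore expected to give about 20 nM, within 8 nM to 60 nM.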

Compound 4, half-maximal effective concentration: 164 nM
Beside the measured number, compound 4's estimate is 8.2-fold (0.91 log units) below it, and the stated range ends below it.
By their numbers in this assay, from the lowest: compounds 2 and 1 (each within the scatter of the next); then compounds 3 and 4 (each within the scatter of the next).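

In this assay, the change reads a 1.9-fold higher number from compound 3 to compound 4 (0.28 log units; within the scatter) and so does not separate cyclopropyl from pyridin-4-yl on this saturated chain carbon; a saturated carbon ring as such does not restore the low numbers of compound 1 and compound 2. The larger steps, a 15-fold higher number from compound 2 to compound 4 (1.17 log units; beyond the scatter) and an 11-fold higher number from compound 1 to compound 4 (1.04 log units; beyond the scatter), show that ring type does not sort this position: compound 2 and compound 4 both carry saturated carbon rings yet lie far apart, as do the aromatic rings of compound 1 and compound 3. No measurement at hand accounts for this pattern.

The compounds shown leave open how the number runs from cyclopropyl to cyclohexyl, which cyclobutyl or cyclopentyl on the same chain carbon would address. Also open, going by these compounds, is how an amine or a carboxylic acid on the cyclohexyl ring would read.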